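This account rests on a few compounds, and the source may have more. Where it says the series, first, only, none or still open, it means among the compounds named here.

Compound 2 `Cn1c(CN2C[C@@H]3C(COc4ccc(Cl)cc4F)[C@@H]3C2)nc2ccccc21` gives 8 nM in an in vitro assay on HEK293 cells with metabotropic glutamate receptor 2 (Rattus norvegicus) as the target, read by FLIPR, in the presence of a further agent that is not named here (a lower number here means that less compound is needed, a higher number that more compound is needed for the effect), the lowest of the two numbers recorded; its nearest neighbour is compound 1 `Cn1c(CN2C[C@@H]3C(COc4ccccc4)[C@@H]3C2)nc2ccccc21`, which in this assay gives 24 nM. Going by the values given here, the single step measured, a 3.0-fold lower number from compound 1 to compound 2 (0.48 log units; beyond the scatter), came from placing 4-chloro-2-fluorophenyl in place of phenyl on the oxygen on a saturated carbon. Compound 3 `Cn1c(CN2C[C@@H]3C(COc4ccc(Cl)cn4)[C@@H]3C2)nc2ccccc21` differs from compound 2 by 5-chloropyridin-2-yl in place of 4-chloro-2-fluorophenyl on an oxygen on a saturated carbon. The measured step bears on this only loosely: it shows that the substituted ring gave a lower number than the bare phenyl, but it says nothing about trading that ring for 5-chloropyridin-2-yl, which keeps a chlorine and drops the fluorine. With no closer comparison at hand, a step of a 1.5-fold higher number from compound 2 to compound 3 (0.18 log units; within the scatter) is expected, that is, no change beyond the scatter in either direction. Compound 3 is therefore estimated at 12 nM in this assay, within a range of 4 nM to 40 nM.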

Compound 3, half-maximal effective concentration: 26 nM
Estimate against measurement, compound 3: 2.2-fold (0.34 log units) below; low and high end bracket the measured number.
By their numbers in this assay, from the lowest: compound 2; then compounds 1 and 3 (each within the scatter of the next).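

In this assay, 5-chloropyridin-2-yl in place of 4-chloro-2-fluorophenyl on the oxygen gives a 3.3-fold higher number from compound 2 to compound 3 (0.51 log units; beyond the scatter) and shows that this position does not treat these two chlorine-bearing rings alike. Set against the bare phenyl, the same ring gives a 1.1-fold higher number from compound 1 to compound 3 (0.03 log units; within the scatter) and so shows that a chlorine on the ring does not by itself bring the lower number seen with compound 2, since compound 3 also carries one. No supporting evidence is available to explain this difference. As far as these compounds go, what a plain 4-chlorophenyl or a 5-fluoropyridin-2-yl group would give at this place remains open, so the shares of the fluorine and the ring nitrogen in the step cannot be separated. Also open, from the compounds shown here alone, is how a methoxy group or a primary amine on the ring would read.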